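A few compounds are considered here, and "the series" means these few. Any claim that something is new, unique, unknown or untested is made for them only; others in the source may bear on it.

Two compounds share a core in which a five-membered non-aromatic ring with one nitrogen carries a phenyl group. Compound 1 `CC(=O)CC1CC(=O)N(c2ccccc2)C1=O` bears a 2-oxopropyl group on a saturated ring carbon, and in an assay on Sf21 cells for inhibition of cytochrome c oxidase subunit 2 (Homo sapiens), read by spectrophotometry, with a stated time of 5 min (on this read-out higher numbers stand for weaker inhibition and lower numbers for stronger inhibition), compound 1 gives 63900 nM. Compound 2 `O=C1CCCC1C1CC(=O)N(c2ccccc2)C1=O` carries a 2-oxocyclopentyl group at that carbon, and in this assay compound 2 gives 51400 nM. Of the two numbers compound 2 has the smaller one, but the step of a 1.2-fold lower number from compound 1 to compound 2 (0.09 log units; within the scatter) is within the scatter, so neither compound can be called the stronger inhibitor. Compound 3 `CC(=O)C(C)(C)C1CC(=O)N(c2ccccc2)C1=O` has not yet been measured; it differs from compound 2 by 1-acetyl-1-methylethyl in place of 2-oxocyclopentyl on a saturated ring carbon. Among the compounds with values here, the only measured step that bears on this change, a 1.2-fold lower number from compound 1 to compound 2 (0.09 log units; within the scatter), swapped one ketone-bearing group for another and stayed within the scatter. A similar outcome is expected here, with no step beyond the scatter, so the estimate is a 1.1-fold higher number from compound 2 to compound 3 (0.03 log units; within the scatter). Compound 3 is therefore expected to give about 55000 nM, within a range from 25000 nM to 120000 nM.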

Compound 3, half-maximal inhibitory concentration: 53500 nM
Compound 3: middle estimate off by 1.0-fold (0.01 log units), on the high side; the range from low to high includes it.
By their numbers in this assay, from the lowest: compounds 2, 3 and 1 (each within the scatter of the next).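

Swapping the ring of the 2-oxocyclopentyl group for the open-chain 1-acetyl-1-methylethyl group, with the same count of heavy atoms, gives a 1.0-fold higher number from compound 2 to compound 3 (0.02 log units; within the scatter) in this assay, so having this ring or not makes no readable difference on this saturated ring carbon in this pair. Branching the chain of the 2-oxopropyl group into 1-acetyl-1-methylethyl gives a 1.2-fold lower number from compound 1 to compound 3 (0.08 log units; within the scatter), so this pair also shows no readable difference. No measurement is available that could explain why these groups read alike.

From the compounds shown here alone, all three groups carry a ketone carbonyl, so it remains open whether an amine, a carboxylic acid or a simple ethyl group at this carbon would stay within the scatter. Substituents on the phenyl group also remain untested in this set.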